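The source may hold more compounds than are shown below. What is called first, only, known or untested is meant among the compounds shown, and "the series" means these compounds.

Of the compounds shown here, three of one shared core have been measured in a functional assay on SF-268 cells (Homo sapiens) for cytotoxicity, read by sulforhodamine B assay, with a stated time of 48 h, tested at 1 uM; on this read-out higher numbers stand for a weaker effect at the one concentration tested and lower numbers for a stronger effect. Compound 1 `COc1ccc(-c2cc(/C=C/C(=O)c3ccc(N)cc3)[nH]n2)cc1` gives 78%. Compound 2 `COc1cc(-c2cc(/C=C/C(=O)c3ccc(N)cc3)[nH]n2)cc(OC)c1OC` gives 81%. Compound 3 `COc1cc(-c2cc(/C=C/C(=O)c3ccc(Cl)c(Cl)c3)[nH]n2)cc(OC)c1OC` gives 92%. Among the compounds with values here, on these numbers compound 2 stands second highest of the three: compound 1 lies within the scatter of it, while compound 3 lies beyond the scatter, the only step measured here being a number 11 percentage points higher from compound 2 to compound 3 (beyond the scatter), which exchanges the group on the carbonyl carbon.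

Compound 4 `COc1ccc(-c2cc(/C=C/C(=O)c3ccc(N)cc3)[nH]n2)cc1OC` differs from compound 2 at the other end of the molecule: hydrogen in place of methoxy on an aromatic carbon. Within the data shown here, no measured step bears directly on this change, since the one measured step alters the carbonyl end instead. The nearest guide is the pair of compound 1 and compound 2, which carry a different number of methoxy groups on that ring yet give values within the scatter of each other. From that, no step beyond the scatter is expected for compound 4 in this assay, and the expected shift is a number 1 percentage points lower from compound 2 to compound 4 (within the scatter). The estimate for compound 4 is 80%, with a range from 70% to 90%.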

Compound 4, a percentage reported as activity, at one concentration (the size of the read-out at that concentration, not a potency): 88%
Compound 4: the middle estimate sits 8 percentage points below what was measured; low and high end bracket the measured number.
By their numbers in this assay, from the lowest: compounds 1, 2, 4 and 3 (each within the scatter of the next, the first and the last beyond it).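

In this assay, hydrogen in place of methoxy on an aromatic carbon ortho to a methoxy group gives a number 7 percentage points higher from compound 2 to compound 4 (within the scatter), so this position accepts the loss of that methoxy group without a step that can be told apart from repeat-measurement noise. The second new step, methoxy in place of hydrogen on an aromatic carbon of the same ring, gives a number 10 percentage points higher from compound 1 to compound 4 (within the scatter), which means that neither single change on this ring, read from compound 4, separates compounds in this read-out. No measurement at hand offers an explanation for these numbers.

Going by these compounds, it remains open whether a different group on the aromatic carbon that changes between compound 2 and compound 4, such as a hydroxyl, a fluorine atom or an ethoxy group, would give a step beyond the scatter. Also open, on these data alone, is whether 3,4-dichlorophenyl in place of 4-aminophenyl on the carbonyl carbon, which gave a number 11 percentage points higher from compound 2 to compound 3 (beyond the scatter), would give a similar step when the ring at the other end carries the methoxy pattern of compound 4.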